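This account rests on a few compounds, and the source may have more. Where it says the series, first, only, none or still open, it means among the compounds named here.

In a functional assay on PC-3 cells (Homo sapiens) for antiproliferative activity, read by sulforhodamine B assay (on this read-out lower numbers stand for stronger inhibition of growth and higher numbers for weaker inhibition of growth), compound 3 `CC(C)COc1cccc(O)c1C(=O)/C=C/c1ccc(O)cc1` stands at 2970 nM and compound 1 `O=C(/C=C/c1ccc(O)cc1)c1c(O)cccc1OCC1CCCC1` at 3040 nM within the scatter of it, while compound 2 `CC(C)CCOc1cccc(O)c1C(=O)/C=C/c1ccc(O)cc1` at 11500 nM holds the clearly higher number. Compound 4 `O=C(/C=C/c1ccc(O)cc1)c1c(O)cccc1OCCC1CCCC1` is still unmeasured. The change from compound 3 is cyclopentylmethyl in place of isopropyl on a saturated chain carbon bound to an oxygen on an aromatic ring (in words, cyclopentylmethyl in place of isopropyl on a saturated chain carbon bound to an oxygen on an aromatic ring), so that isobutoxy becomes 2-cyclopentylethoxy. With a 1.0-fold lower number from compound 1 to compound 3 (0.01 log units; within the scatter) isopropyl in place of cyclopentyl leaves the number unmoved. With a 3.9-fold lower number from compound 2 to compound 3 (0.59 log units; beyond the scatter) isopropyl in place of isobutyl counts for more, and a 3.8-fold higher number from compound 1 to compound 2 (0.58 log units; beyond the scatter) shows the same gap from the other side. Compound 4 carries cyclopentylmethyl where compound 1 carries cyclopentyl, the same kind of change as isobutyl where compound 3 carries isopropyl. Among the measured compounds shown here, that comparison rests on a single pair, and no other compound with the 2-cyclopentylethoxy group has been measured. A higher number is therefore expected, with a 2.7-fold higher number from compound 3 to compound 4 (0.43 log units; beyond the scatter) as the estimated step, a little smaller than the gap seen with compound 2. Compound 4 is estimated at 8000 nM with an expected range from 3000 nM to 20000 nM as the working figure.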

Compound 4, concentration for 50% growth inhibition: 3480 nM
Beside the measured number, compound 4's estimate is 2.3-fold (0.36 log units) above it, within the range that was stated.
By their numbers in this assay, from the lowest: compounds 3, 1 and 4 (each within the scatter of the next); then compound 2.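

In this assay, the 2-cyclopentylethoxy group gives a number that cannot be told apart from those of the two best compounds: cyclopentylmethyl in place of isopropyl gives a 1.2-fold higher number from compound 3 to compound 4 (0.07 log units; within the scatter), and cyclopentylmethyl in place of cyclopentyl gives a 1.1-fold higher number from compound 1 to compound 4 (0.06 log units; within the scatter). Compound 2 now stands alone among the four, with cyclopentyl in place of isopropyl on the saturated chain carbon, two bonds along the chain from the oxygen on the aromatic ring, giving a 3.3-fold lower number from compound 2 to compound 4 (0.52 log units; beyond the scatter), so adding to the chain does not by itself raise the number at this position. The effect of exchanging cyclopentyl and isopropyl depends on the chain that carries them, and the two readings of that exchange disagree: the same change on two cores in this assay, a 1.0-fold lower number (0.01 log units; within the scatter) from compound 1 to compound 3 and a 3.3-fold higher number (0.52 log units; beyond the scatter) from compound 4 to compound 2, 3.4-fold (0.53 log units) apart, beyond the scatter of two such steps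

On these data alone, whether the high number of compound 2 is a lone exception or part of a wider trend among open-chain ethers remains open. Also open, as far as these compounds go, is how the number would respond to a longer chain such as 3-cyclopentylpropoxy, a cyclohexyl ring in place of the cyclopentyl ring, or a terminal amine on the same chain.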